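This account rests on a few compounds, and the source may have more. Where it says the series, first, only, none or still open, it means among the compounds named here.

In an ADME assay on PC-3 cells (Homo sapiens) for cytotoxicity, read by WST assay, tested at 100 uM (on this read-out higher numbers stand for more inhibition at the one concentration tested (going by the name of the read-out) and lower numbers for less inhibition), compound 1 `O=C(Nc1cccc(Oc2ccccc2)c1)C1CCCN(C(=O)c2cccc(-c3ccco3)c2)C1` gives 0%. Compound 2 `COC(=O)c1cccc(C(=O)N2CCCC(C(=O)Nc3ccc(Cl)cc3)C2)c1`, which shares the same core, gives 0% in this assay and therefore stands level with compound 1, within the usual scatter. Compound 3 `Cc1nc(-c2cccc(C(=O)N3CCCC(C(=O)Nc4ccc(Cl)cc4)C3)c2)cs1` has not yet been measured. It differs from compound 2 in one place: 2-methyl-1,3-thiazol-4-yl in place of methoxycarbonyl on an aromatic carbon. The two measured values do not show any step beyond the scatter, so the expected step of a number 5 percentage points higher from compound 2 to compound 3 (within the scatter) is small, in no clear direction. Compound 3 is estimated to give 5% in this assay, with a likely range from 0% to 25%.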

Compound 3, a percentage reported as inhibition, at one concentration (the size of the read-out at that concentration, not a potency): 1%
Compound 3: middle estimate off by 4 percentage points, on the high side; measured number inside the range.
By their numbers in this assay, from the lowest: compounds 1, 2 and 3 (each within the scatter of the next).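

In this assay, placing 2-methyl-1,3-thiazol-4-yl instead of methoxycarbonyl on this aromatic carbon gives a number 1 percentage points higher from compound 2 to compound 3 (within the scatter). Within the data shown here, this is the first step read at this position, and it shows that a five-membered aromatic ring with 2 hetero atoms can replace an open ester group without moving the read-out beyond the scatter. Nothing available explains this result.

Still open, going by these compounds, is whether any group on this aromatic carbon can move the read-out beyond the scatter. A carboxylic acid or an amine here could behave differently from both groups seen so far.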